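The compounds below may be only part of what the source reports. "The series", "measured", "known", "first", "only" and "open" are said of these compounds alone.

Compound 3, `CNC(=O)[C@@]12C[C@@H]1[C@@H](n1cnc3c(NC)nc(C#Cc4ccsc4)nc31)[C@H](O)[C@@H]2O`, gives 11% in an assay on CHO cells for displacement of a labelled ligand from adenosine receptor A1 (Homo sapiens), read by scintillation counting, with a stated time of 60 min, tested at 10 uM (on this read-out lower numbers stand for less inhibition and higher numbers for more inhibition at the one concentration tested (going by the name of the read-out)), the lowest of the three numbers, though the gaps to its companions are within the scatter. Compound 1, `CNC(=O)[C@@]12C[C@@H]1[C@@H](n1cnc3c(NC)nc(C#Cc4ccccc4)nc31)[C@H](O)[C@@H]2O`, gives 18% in this assay, and compound 2, `CNC(=O)[C@@]12C[C@@H]1[C@@H](n1cnc3c(NC)nc(C#Cc4ccc(-c5ccccc5)cc4)nc31)[C@H](O)[C@@H]2O`, gives 18%. The measured steps are all small: no change at the digits printed from compound 1 to compound 2 (within the scatter), a number 7 percentage points lower from compound 1 to compound 3 (within the scatter), and a number 7 percentage points lower from compound 2 to compound 3 (within the scatter). None of them rises above the scatter, so across these three groups on the triple-bonded carbon the read-out has stayed flat.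

Compound 4, `CNC(=O)[C@@]12C[C@@H]1[C@@H](n1cnc3c(NC)nc(C#Cc4nccs4)nc31)[C@H](O)[C@@H]2O`, differs from compound 3 by 1,3-thiazol-2-yl in place of thiophen-3-yl on a triple-bonded carbon. Among the measured compounds shown here, the steps that bear on this change are the two exchanges of the group on the triple-bonded carbon, which were within the scatter, so no step beyond the scatter is expected here either. The expected step is a number 2 percentage points higher from compound 3 to compound 4 (within the scatter). Compound 4 is therefore estimated to give 13% in this assay, with a range from 0% to 35%.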

Compound 4, a percentage reported as inhibition, at one concentration (the size of the read-out at that concentration, not a potency): 31%
Estimate against measurement, compound 4: 18 percentage points below; the measured number falls inside the stated range.
By their numbers in this assay, from the lowest: compounds 3, 1 and 2 (each within the scatter of the next); then compound 4.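

The group on the triple-bonded carbon is not as indifferent in this assay as the earlier exchanges suggested: compound 4 stands apart from the other three, with a number 20 percentage points higher from compound 3 to compound 4 (beyond the scatter) and a number 13 percentage points higher from compound 1 to compound 4 (beyond the scatter) and also a number 13 percentage points higher from compound 2 to compound 4 (beyond the scatter) on this read-out. Thiophen-3-yl and 1,3-thiazol-2-yl have the same number of heavy atoms and are both five-membered aromatic rings, so the change that separates compound 3 from compound 4 is a ring nitrogen and a further hydrogen-bond acceptor, not ring size. Nothing available explains why this exchange moves the read-out.

Going by these compounds, it remains open whether the rise follows from the ring nitrogen itself or from where it sits in the ring. On these data alone, it is also open whether a pyridin-2-yl ring or an aminomethyl chain on the triple-bonded carbon would behave the same way.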